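A few compounds are considered here, and "the series" means these few. Any claim that something is new, unique, unknown or untested is made for them only; others in the source may bear on it.

In a functional assay on A549 cells (Homo sapiens) for antiproliferative activity, read by MTT assay, with a stated time of 48 h (a higher number here means a weaker inhibitor, a lower number a stronger inhibitor), compound 1 (`COc1ccc(N(C)c2ccnc(Cl)n2)cc1O`) gives 381 nM and compound 2 (`COc1ccc(N(C)c2ccnc(Cl)n2)cc1OCCCBr`) gives 862 nM, the higher of the two numbers. These compounds differ by a 3-bromopropyl in place of hydrogen on an oxygen on an aromatic ring, and the measured change is a 2.3-fold higher number from compound 1 to compound 2 (0.35 log units; beyond the scatter). Compound 3 (`COc1ccc(N(C)c2ccnc(Cl)n2)cc1OCCC[Se]C#N`), not yet measured in this assay, changes the end of that chain: a group of 3 heavy atoms (1 carbon, 1 nitrogen, 1 selenium; no ring) in place of one bromine atom, on a saturated chain carbon, three bonds along the chain from an oxygen on an aromatic ring. Going by the values given here, no measured step covers this replacement, so the only guide is that single modest step, which shows how far a change at this oxygen has moved the number so far. A shift of similar modest size is expected, towards a lower number, though the direction remains uncertain. The expected move is a 2.9-fold lower number from compound 2 to compound 3 (0.46 log units; beyond the scatter). For compound 3 the estimated value is 300 nM, with an expected range from 70 nM to 1000 nM.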

Compound 3, half-maximal inhibitory concentration: 3710 nM
Beside the measured number, compound 3's estimate is 12-fold (1.09 log units) below it, and the stated range ends below it.
By their numbers in this assay, from the lowest: compound 1; then compound 2; then compound 3.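

In this assay, the end of the chain matters in its own right: a group of carbon, nitrogen and selenium in place of bromine gives a 4.3-fold higher number from compound 2 to compound 3 (0.63 log units; beyond the scatter), so the number depends on what the chain carries and not only on the chain being present. Both changes at this oxygen raise the number, and replacing the hydrogen on the oxygen with the whole selenium-bearing chain gives a 9.7-fold higher number from compound 1 to compound 3 (0.99 log units; beyond the scatter), which leaves compound 1 the lowest of the three. Nothing available here accounts for this rise.

The compounds shown leave open how a chain ending in an amine or a carboxylic acid would read. They also do not show whether a shorter or longer chain carrying the same selenium group would shift the number.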